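Acetal methoxy removal in the spiro pyrazole series

The source may hold more compounds than are shown below. What is called first, only, known or untested is meant among the compounds shown, and "the series" means these compounds.

Measured so far:
compound 1, `CCCCCN1CCC2(CC1)OC(OC)Cc1c2cnn1-c1ccccc1`, 0.82 nM in an assay for displacement of a labelled ligand from Sigma non-opioid intracellular receptor 1 (Cavia porcellus), read by scintillation counting, with a stated time of 180 min; a higher number here means a weaker inhibitor, a lower number a stronger inhibitor
compound 2, `C=C(C)CCN1CCC2(CC1)OC(OC)Cc1c2cnn1-c1ccccc1`, 1.6 nM in this assay

Compound 2 and compound 1 sit within the scatter of each other: a 2.0-fold higher number from compound 1 to compound 2 (0.29 log units; within the scatter). Nothing in these two numbers sets compound 2 apart from compound 1.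

Compound 3, `C=C(C)CCN1CCC2(CC1)OCCc1c2cnn1-c1ccccc1`, is not yet measured. It differs from compound 2 by hydrogen in place of methoxy on a saturated ring carbon. Among the measured compounds shown here, the only measured step concerns the chain on the amine nitrogen, not this ring carbon, so no step bears directly on the change. With the shared core otherwise kept and the amine chain of compound 2 unchanged, the expected step from compound 2 to compound 3 is a 1.3-fold higher number from compound 2 to compound 3 (0.10 log units; within the scatter), none beyond the scatter. Compound 3 is therefore estimated at 2 nM, within 0.6 nM to 7 nM.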

Compound 3, inhibition constant: 0.97 nM
The estimate for compound 3 lay 2.1-fold (0.31 log units) above the measured number; the measured number falls inside the stated range.
By their numbers in this assay, from the lowest: compounds 1, 3 and 2 (each within the scatter of the next).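

Hydrogen in place of methoxy on a saturated ring carbon, next to the ring oxygen, is the first change at this position, and in this assay it gives a 1.6-fold lower number from compound 2 to compound 3 (0.22 log units; within the scatter) with the amine chain of compound 2 kept. In this one pair, the methoxy can therefore leave without a step beyond the scatter, so the acetal methoxy is not required for a value in this range. No supporting measurement bears on why this position behaves this way.

The compounds shown leave open whether a hydroxyl, an ethoxy or an amine at this ring carbon would also stay within the scatter. They also leave open whether the same removal would behave alike with the amine chain of compound 1.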